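Anilide series: bromo in place of fluoro

The source may hold more compounds than are shown below. What is called first, only, known or untested is meant among the compounds shown, and "the series" means these compounds.

Compound 1, `COc1cccc(NC(=O)c2ccc3cccc(O)c3n2)c1`, gives 2.5 in a physicochemical assay for lipophilicity, read by HPLC; on this read-out lower numbers stand for lower lipophilicity and higher numbers for higher lipophilicity.
Compound 2, `COc1ccc(NC(=O)c2ccc3cccc(O)c3n2)cc1`, gives 2.5.
Compound 3, `O=C(Nc1ccccc1F)c1ccc2cccc(O)c2n1`, gives 2.5.

In this assay compound 3 stands level with compounds 1 and 2 at the digits shown; the differences among the three lie within the scatter, so no order among them is claimed. Compound 4, `O=C(Nc1ccccc1Br)c1ccc2cccc(O)c2n1`, differs from compound 3 by bromo in place of fluoro on an aromatic carbon. Among the measured compounds shown here, no pair of measured compounds shows this change, so its size is not known from the series itself. The step from compound 3 to compound 4 is expected to be a number 0.60 log units higher from compound 3 to compound 4 (beyond the scatter), upward and beyond the scatter. Compound 4 is estimated at 3.1, with a range from 2.7 to 3.5.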

Compound 4, partition coefficient: 2.5
Estimate against measurement, compound 4: 0.60 log units above, and the stated range ends above it.
By their numbers in this assay, from the lowest: compounds 1, 2, 3 and 4 (each within the scatter of the next).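

Bromo in place of fluoro on an aromatic carbon, ortho to a large group, gives no change at the digits printed from compound 3 to compound 4 (within the scatter) in this assay. Among the compounds shown here, this is the first single-place step, and at this position it separates 2-fluorophenyl from 2-bromophenyl by nothing that can be read. No measurement at hand bears on why the read-out holds.

Open, going by these compounds, is whether an amine or a carboxylic acid on the same aromatic carbon would move the read-out in this assay, and so whether this position can give a step beyond the scatter at all.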